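Swapping ethoxy for trifluoromethyl on the shared core

The source may hold more compounds than are shown below. What is called first, only, known or untested is meant among the compounds shown, and "the series" means these compounds.

Measured so far in a functional assay on A-375 cells (Homo sapiens) for antiproliferative activity, read by MTT assay, with a stated time of 24 h; a higher number here means a weaker inhibitor, a lower number a stronger inhibitor:
- compound 1 `Cc1c(C(=O)Nc2c(F)cc(-c3cccc(F)c3)cc2F)nc2ccc(F)cc2c1C(=O)O`: 81900 nM
- compound 2 `CCOc1ccc2nc(C(=O)Nc3c(F)cc(-c4cccc(F)c4)cc3F)c(C)c(C(=O)O)c2c1`: 14900 nM

Of these two compounds, compound 2 has the lower number at 14900 nM, which makes it the stronger inhibitor, while compound 1 stands at 81900 nM. The next compound, compound 3 `Cc1c(C(=O)Nc2c(F)cc(-c3cccc(F)c3)cc2F)nc2ccc(C(F)(F)F)cc2c1C(=O)O`, has trifluoromethyl in place of ethoxy on an aromatic carbon.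

For the measured compounds named here, one measured step bears on this change: a 5.5-fold lower number from compound 1 to compound 2 (0.74 log units; beyond the scatter). That modest step, beyond the scatter, put ethoxy in place of fluoro on the same aromatic carbon. Compound 3 loses that ethoxy, so the gain seen in that single step may be lost as well, and a number closer to that of compound 1 seems likely. Going by the values given here, no compound with trifluoromethyl has been measured, so the uncertainty is wide. The expected change is a 3.0-fold higher number from compound 2 to compound 3 (0.48 log units; beyond the scatter), toward a higher number. For compound 3 the estimated value is 45000 nM, with an expected range of 15000 nM to 130000 nM.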

Compound 3, half-maximal inhibitory concentration: 42800 nM
Compound 3: the middle estimate sits 1.1-fold (0.02 log units) above what was measured, within the range that was stated.
By their numbers in this assay, from the lowest: compound 2; then compounds 3 and 1 (each within the scatter of the next).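

The earlier compounds shown here showed only that ethoxy gave a lower number than fluoro at this position on the shared core; trifluoromethyl now adds a third group for comparison. In this assay, for the compounds shown here, the change from ethoxy to trifluoromethyl gives a 2.9-fold higher number from compound 2 to compound 3 (0.46 log units; beyond the scatter), so the advantage seen with ethoxy does not carry over to this other group, while the comparison with fluoro gives a 1.9-fold lower number from compound 1 to compound 3 (0.28 log units; within the scatter), which leaves trifluoromethyl and fluoro indistinguishable here and ethoxy as the only one of the three groups that stands apart. Nothing measured here explains why these groups compare as they do.

Ethoxy differs from trifluoromethyl in both its oxygen and its two-carbon chain, and methoxy, propoxy or a plain ethyl group at this position could help show which of these features goes with the lower number. Going by these compounds, it also remains open whether a different kind of group, such as an amine or a hydroxyl, would go beyond compound 2, which at 14900 nM has the lowest number of the three.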